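Demethylation of the added methoxy in compound 2

The source may hold more compounds than are shown below. What is called first, only, known or untested is meant among the compounds shown, and "the series" means these compounds.

Compound 1 `COc1ccc([C@@H]2CCc3c(OC)cc(OC)cc3O2)cc1` is the reference point: in a functional assay on U-937 cells (Homo sapiens) for antiproliferative activity, read by WST assay, with a stated time of 72 h (on this read-out lower numbers stand for stronger inhibition and higher numbers for weaker inhibition), compound 1 gives 18000 nM. Compound 2 `COc1ccc([C@@H]2CCc3c(OC)cc(OC)cc3O2)c(OC)c1` carries one methoxy more. In this assay compound 2 gives only a limit, > 100000 nM, not a number. Among the compounds with values here, the single measured step, an at least 5.5-fold higher number from compound 1 to compound 2 (0.74 log units; beyond the scatter), shows that methoxy in place of hydrogen on an aromatic carbon moves the read-out to weaker inhibition; how far remains open because the limit of > 100000 nM in this assay, at which 1 of the 2 values shown sits, is where the value of compound 2 sits. Compound 3 `COc1ccc([C@@H]2CCc3c(OC)cc(OC)cc3O2)c(O)c1` differs from compound 2 by hydrogen in place of methyl on an oxygen on an aromatic ring; cut one bond further out, the same difference reads methoxy to hydroxy. Within the data shown here, no measured step covers a hydroxy on that ring. The step from compound 1 to compound 2 bears on it only in that the group added there is reduced again, so compound 3 is expected to land between compound 1 and compound 2 rather than past either. The expected step of an at least 2.0-fold lower number from compound 2 to compound 3 (0.30 log units; that floor lies within the scatter) is therefore read against a limit and carries little weight. Compound 3 is estimated at 50000 nM, within 15000 nM to 150000 nM, with a real chance that only a limit is reported again.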

Compound 3, half-maximal inhibitory concentration: 2900 nM
Compound 3: the middle estimate sits 17-fold (1.24 log units) above what was measured; measured number outside the range, below it.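

In this assay this aromatic carbon tolerates more than the methoxy of compound 2 suggested: hydroxy in place of hydrogen gives a 6.2-fold lower number from compound 1 to compound 3 (0.79 log units; beyond the scatter), so a substituent here can strengthen inhibition as well as weaken it. The outcome therefore depends on the group and not merely on whether the place is occupied, since methoxy in place of hydrogen gives an at least 5.5-fold higher number from compound 1 to compound 2 (0.74 log units; beyond the scatter), whereas hydrogen in place of methyl on the oxygen on the aromatic ring gives an at least 34-fold lower number from compound 2 to compound 3 (1.53 log units; beyond the scatter) and takes the read-out past compound 1 rather than back to it. The size of that last step is only a floor because compound 2 stands at a limit, not at a number: the limit of > 100000 nM in this assay, at which 1 of the 3 values shown sits.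

On these data alone, whether the gain requires a hydroxy specifically, or whether an amine or a carboxylic acid on the same aromatic carbon would give a similar read-out, remains open. Also open, as far as these compounds go, is whether the ranking of hydrogen, methoxy and hydroxy at this place holds in any read-out other than this assay, as these three compounds are compared in that one only.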